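The source may hold more compounds than are shown below. What is called first, only, known or untested is meant among the compounds shown, and "the series" means these compounds.

In a functional assay on Caco-2 cells (Homo sapiens) for cytotoxicity, read by MTT assay, with a stated time of 24 h (on this read-out lower numbers stand for stronger inhibition and higher numbers for weaker inhibition), compound 1, whose structure is `NS(=O)(=O)c1ccc(NC2=NC(=O)/C(=C/c3ccccc3)S2)cc1`, gives 334 nM. Compound 2, with structure `COc1ccc(/C=C2\SC(Nc3ccc(S(N)(=O)=O)cc3)=NC2=O)cc1`, is its close relative; in this assay compound 2 gives 1330 nM. The change between them is methoxy in place of hydrogen on an aromatic carbon, and it produced a 4.0-fold higher number from compound 1 to compound 2 (0.60 log units; beyond the scatter).

Compound 3, with structure `NS(=O)(=O)c1ccc(Nc2nc3nc(=S)[nH]c(-c4ccccc4)c3s2)cc1`, is built on a different core, and the difference between the two cores is not broken down here. In this assay compound 3 gives 333 nM. Compound 3 and compound 1 give numbers that lie within the usual scatter of each other, so nothing separates them on this read-out.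

Compound 4, with structure `COc1ccc(-c2[nH]c(=S)nc3nc(Nc4ccc(S(N)(=O)=O)cc4)sc23)cc1`, has not yet been measured. Among the compounds with values here, it differs from compound 3 by methoxy in place of hydrogen on an aromatic carbon, which is the same change, at the same kind of place, as the one between compound 1 and compound 2. Since that earlier change gave a 4.0-fold higher number from compound 1 to compound 2 (0.60 log units; beyond the scatter), the most natural expectation is a step of a similar direction, though its size on a different core is uncertain. For compound 4 the expected step is a 3.0-fold higher number from compound 3 to compound 4 (0.48 log units; beyond the scatter), because the only measured case of this change is a 4.0-fold higher number from compound 1 to compound 2 (0.60 log units; beyond the scatter). The estimated value for compound 4 in this assay is therefore 1000 nM, with a plausible range from 400 nM to 2500 nM.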

Compound 4, half-maximal inhibitory concentration: 667 nM
The estimate for compound 4 lay 1.5-fold (0.18 log units) above the measured number, and the stated range covers the measured number.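

On the core of compound 3, putting methoxy in place of hydrogen on the aromatic ring gives a 2.0-fold higher number from compound 3 to compound 4 (0.30 log units; within the scatter) in this assay, so this step on its own cannot be told apart from the ordinary variation between repeated measurements. Set beside the step on the core of compound 1, which did lie beyond that variation, the two steps cannot be told apart either: the same change on two cores in this assay, a 4.0-fold higher number (0.60 log units; beyond the scatter) from compound 1 to compound 2 and a 2.0-fold higher number (0.30 log units; within the scatter) from compound 3 to compound 4, 2.0-fold (0.30 log units) apart, within the scatter of two such steps. This means that nothing in these two pairs speaks against carrying the change from one core to the other, but it does not show that the change has the same size on both cores, and two pairs, one of them within the scatter, make no general rule for the series.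

The compounds shown carry only hydrogen or methoxy at this place on the ring, so it remains open what a chlorine atom, an amine, a carboxylic acid or a longer chain such as butoxy would do there on either core. As far as these compounds go, it also remains open whether the two steps would compare in the same way in any read-out other than this assay.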